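Swapping an aryl for a sec-butyl on the amide nitrogen

The source may report more compounds than this note shows. Statements on the series, on what has been measured and on what is new or still open speak of the compounds shown alone.

Compound 1 `Cc1ccc(OCC(=O)N(Cc2cccs2)c2cccnc2)cc1` is the more potent of the two measured aryloxyacetamides. In an assay on HEK293 cells for agonist activity at transient receptor potential cation channel subfamily M member 8 (Homo sapiens), read by fluorescence and calcium flux, with a stated time of 15 min (on this read-out higher numbers stand for an effect only at larger amounts of compound and lower numbers for an effect already at smaller amounts), compound 1 gives 198 nM, while compound 2 `CCN(Cc1cncs1)C(=O)COc1ccc(C)cc1` gives 1100 nM in this assay; the two compounds differ in more than one place, so their values are simply set side by side. Compound 3 `CCC(C)N(Cc1cccs1)C(=O)COc1ccc(C)cc1` carries the change (sec-butyl in place of pyridin-3-yl on an amide-type nitrogen), so that an alkyl group rather than an aromatic ring sits on the amide nitrogen. Within the data shown here, no measured pair isolates this change. Among the measured compounds shown here, the only measured compound with a plain alkyl on that nitrogen is compound 2, whose value of 1100 nM is weaker than that of compound 1, which is taken as a hint that the step of a 3.0-fold higher number from compound 1 to compound 3 (0.48 log units; beyond the scatter) is expected to be a modest loss in this assay. Compound 3 is therefore estimated at 600 nM, within a range of 150 nM to 2500 nM.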

Compound 3, half-maximal effective concentration: 2000 nM
Estimate against measurement, compound 3: 3.3-fold (0.52 log units) below, within the range that was stated.
By their numbers in this assay, from the lowest: compound 1; then compounds 2 and 3 (each within the scatter of the next).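

Among these compounds, the step from this assay gives the first direct reading of this position: with sec-butyl in place of pyridin-3-yl on the amide-type nitrogen, the result is a 10-fold higher number from compound 1 to compound 3 (1.00 log units; beyond the scatter) with the rest of the molecule unchanged. The earlier compounds shown here differed in more than one place and could only hint at this, whereas this matched pair shows that the group on this nitrogen affects the value and that, of these two groups, pyridin-3-yl gives the lower number. No measurement here accounts for the difference between the two groups.

A single pair cannot show whether the ring as a whole or its hetero nitrogen matters, and a plain phenyl on this nitrogen would bear on that question. As far as these compounds go, whether a cyclohexyl or an isopropyl would behave like sec-butyl also remains open.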